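Methylsulfanyl in place of trifluoromethyl: expectation for compound 4

The source may report more compounds than this note shows. Statements on the series, on what has been measured and on what is new or still open speak of the compounds shown alone.

Of the compounds shown here, three sharing one core have been read in an ADME assay on MDCK cells (Canis lupus familiaris) for cytotoxicity; on this read-out higher numbers stand for lower toxicity in this test and lower numbers for higher toxicity in this test. Compound 2 `O=[N+]([O-])C1=NNc2nc(C(F)(F)F)nn2C1c1c(O)cc(O)cc1O` gives 252000 nM and compound 1 `CSc1nc2n(n1)C(c1ccc(O)cc1O)C([N+](=O)[O-])=NN2` gives 201000 nM, two numbers within the scatter of each other. Compound 3 `O=[N+]([O-])C1=NNc2nc(C(F)(F)F)nn2C1c1ccc(O)cc1O` gives 108000 nM. Hydrogen in place of hydroxy on an aromatic carbon accounts for a 2.3-fold lower number from compound 2 to compound 3 (0.37 log units; beyond the scatter), a modest step beyond the scatter.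

Compound 4 `CSc1nc2n(n1)C(c1c(O)cc(O)cc1O)C([N+](=O)[O-])=NN2` is still unread. Its structure departs from compound 2 by methylsulfanyl in place of trifluoromethyl on an aromatic carbon, between two ring nitrogen atoms: methylsulfanyl in place of trifluoromethyl on an aromatic carbon.

One measured pair carries the same swap in the opposite direction. Trifluoromethyl in place of methylsulfanyl gives a 1.9-fold lower number from compound 1 to compound 3 (0.27 log units; within the scatter), a step within the scatter. Read backwards, that pair points towards a higher number for compound 4, but only weakly, as it is a single pair and it lacks the extra hydroxy of compound 2. The data do not show whether the swap behaves alike with that hydroxy present.

In this assay the expected move is small and upward, with no clear step beyond the scatter. The estimated change is a 1.4-fold higher number from compound 2 to compound 4 (0.14 log units; within the scatter). Compound 4 is expected at 350000 nM, with an estimated range of 170000 nM to 700000 nM.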

Compound 4, half-maximal cytotoxic concentration: 877000 nM
Estimate against measurement, compound 4: 2.5-fold (0.40 log units) below, outside the stated range (above it).
By their numbers in this assay, from the lowest: compounds 3, 1 and 2 (each within the scatter of the next, the first and the last beyond it); then compound 4.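

In this assay, within the data shown here, methylsulfanyl in place of trifluoromethyl on the aromatic carbon between two ring nitrogen atoms now gives a step beyond the scatter with the extra hydroxy present, a 3.5-fold higher number from compound 2 to compound 4 (0.54 log units; beyond the scatter), whereas the only earlier pair for this swap stayed within the scatter. The swap therefore points the same way on both cores, and the two steps do not differ in size beyond what repeat measurements allow: the same change on two cores in this assay, a 1.9-fold lower number (0.27 log units; within the scatter) from compound 1 to compound 3 and a 3.5-fold lower number (0.54 log units; beyond the scatter) from compound 4 to compound 2, 1.9-fold (0.27 log units) apart, within the scatter of two such steps. The hydroxy change also carries over to the methylsulfanyl series, a 4.4-fold higher number from compound 1 to compound 4 (0.64 log units; beyond the scatter), so the two changes so far read as roughly independent of each other across these four compounds: the same change on two cores in this assay, a 2.3-fold lower number (0.37 log units; beyond the scatter) from compound 2 to compound 3 and a 4.4-fold lower number (0.64 log units; beyond the scatter) from compound 4 to compound 1, 1.9-fold (0.27 log units) apart, within the scatter of two such steps.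

Only trifluoromethyl and methylsulfanyl are shown on this carbon, so the behaviour of an amine, a methoxy or a longer chain such as ethylsulfanyl there remains open. The four compounds also cannot separate the contribution of the sulfur atom from that of the departing fluorine atoms, and they show nothing outside this one cytotoxicity read-out on a single cell line.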